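This account rests on a few compounds, and the source may have more. Where it says the series, first, only, none or still open, it means among the compounds named here.

Measured so far:
compound 1 `C[C@@H](CF)OC(=O)N1CCC(O[C@H]2CC[C@H](Oc3cnc(S(C)(=O)=O)cn3)CC2)CC1` — 105%
compound 2 `CS(=O)(=O)c1cnc(O[C@H]2CC[C@H](OC3CCN(C(=O)C4(C(F)(F)F)CCCC4)CC3)CC2)cn1` — 95%

In a functional assay on isolated protein for agonist activity at Glucose-dependent insulinotropic receptor (Homo sapiens), read by HTRF and cAMP accumulation (on this read-out lower numbers stand for smaller maximal responses and higher numbers for larger maximal responses), compound 1 reaches 105%, and compound 2 reaches 95%. The two numbers sit within the usual scatter of one another: a number 10 percentage points lower from compound 1 to compound 2 (within the scatter). Compound 2 therefore stands with compound 1 as a full response on this read-out, and nothing separates them beyond repeat-measurement noise.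

Compound 3 `CS(=O)(=O)c1cnc(O[C@H]2CC[C@H](OC3CCN(CC4(C(F)(F)F)CC4)CC3)CC2)cn1` carries the change (a group of 8 heavy atoms (5 carbon, 3 fluorine; one three-membered non-aromatic ring of carbon only) in place of a group of 11 heavy atoms (7 carbon, 1 oxygen, 3 fluorine; one five-membered non-aromatic ring of carbon only), on an amine nitrogen in a ring). Among the measured compounds shown here, the only measured step, from compound 1 to compound 2, concerned the group on the carbonyl carbon and left the value essentially where it was; it does not touch the amine nitrogen in the ring, so no measured step bears directly on the change to compound 3. What the two measured compounds show is that both arrangements of the group on that nitrogen side give a largest response close to the reference. Compound 3 is therefore expected to stay in the same band, with a step of about no change at the digits printed from compound 2 to compound 3 (within the scatter) in this assay, none beyond the scatter. The estimate for compound 3 is 95%, with a range from 70% to 115%.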

Compound 3, largest response reached (Emax), in percent of the reference or control that the assay uses: 116%
Compound 3: the middle estimate sits 21 percentage points below what was measured; the measured number lies above the stated range.
By their numbers in this assay, from the lowest: compounds 2 and 1 (each within the scatter of the next); then compound 3.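

In this assay, the group on the amine nitrogen in a ring now proves able to move the largest response, a shift that the two carbonyl-bearing groups of compound 1 and compound 2 did not show between themselves. With (1-(trifluoromethyl)cyclopropyl)methyl entering, the read-out rises on both available comparisons (a number 21 percentage points higher from compound 2 to compound 3 (beyond the scatter)) and (a number 11 percentage points higher from compound 1 to compound 3 (beyond the scatter)), which puts compound 3 clearly on top of the three and shows that a carbonyl on this nitrogen is not needed for a full response. No measurement at hand accounts for this rise.

The entering group changes several features at once, so the compounds shown leave open whether the gain belongs to the trifluoromethyl, the three-membered ring or the loss of the carbonyl, and a plain cyclopropylmethyl or a 2,2,2-trifluoroethyl group on the same nitrogen would help to separate these. As far as these compounds go, the shared core stays fixed across all three compounds, so it is also open whether the higher response would persist with a nitrile in place of the methylsulfonyl group.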